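Series notes: aryl swap on the cyclopropane of compound 3

This account rests on a few compounds, and the source may have more. Where it says the series, first, only, none or still open, it means among the compounds named here.

Three compounds of the series have numbers in a functional assay for agonist activity at G protein-coupled receptor 88 (Homo sapiens), read by HTRF and cAMP accumulation; on this read-out higher numbers stand for an effect only at larger amounts of compound and lower numbers for an effect already at smaller amounts. Compound 1 `CC(C)(C)[C@H](N)CN(C(=O)[C@@H]1C[C@H]1c1ccccc1)c1ccc(-c2ccccc2)cc1` gives 11 nM. Going by the values given here, compound 2 `CCC(CC)C(N)CCN(C(=O)[C@@H]1C[C@H]1c1ccccc1)c1ccc(-c2ccccc2)cc1` gives 2 nM; the only one-place step measured so far, a 5.5-fold lower number from compound 1 to compound 2 (0.74 log units; beyond the scatter), concerns the amine-bearing chain. Compound 3 `CC[C@H](C)[C@H](N)CN(C(=O)[C@@H]1C[C@H]1c1ccc(F)cc1)c1ccc(-c2ccccc2)cc1` gives 600 nM, the highest number of the three, its gaps to compound 1 and compound 2 both beyond the scatter, so compound 3 is the weakest measured agonist here.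

Compound 4 `CC[C@H](C)[C@H](N)CN(C(=O)[C@@H]1C[C@H]1c1ccsc1)c1ccc(-c2ccccc2)cc1` differs from compound 3 by thiophen-3-yl in place of 4-fluorophenyl on a saturated ring carbon. Among the compounds with values here, no measured step touches this position: compounds 1 and 2 carry an unsubstituted phenyl on the cyclopropane but also a different amine chain, so their gap to compound 3 cannot be assigned to the aryl group alone. With nothing in this assay that speaks for the direction of an aryl change, the expectation for compound 4 is a number close to that of compound 3, the step of a 1.5-fold lower number from compound 3 to compound 4 (0.18 log units; within the scatter) estimated not to clear the scatter. Compound 4 is accordingly expected at 400 nM, within 120 nM to 1500 nM.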

Compound 4, half-maximal effective concentration: 450 nM
The estimate for compound 4 lay 1.1-fold (0.05 log units) below the measured number; the measured number falls inside the stated range.
By their numbers in this assay, from the lowest: compound 2; then compound 1; then compounds 4 and 3 (each within the scatter of the next).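

In this assay, going by these compounds alone, thiophen-3-yl in place of 4-fluorophenyl on the saturated ring carbon gives a 1.3-fold lower number from compound 3 to compound 4 (0.12 log units; within the scatter) and is the first measured step at this position. With the amine chain held constant, this exchange of a six-membered aromatic ring of carbon only for a five-membered aromatic ring with one hetero atom therefore leaves the number within the scatter, and the fluorine is not needed to keep it there. No measurement at hand speaks to the reason for this result.

Open, on these data alone, is whether an unsubstituted phenyl, a pyridine ring or a furan ring at this carbon would also stay within the scatter of compound 3 on the same amine chain. Also open, as far as these compounds go, is whether the same aryl exchange would leave the number as little moved on the 2-amino-3-ethylpentyl chain of compound 2.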